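Triterpenoid diols: formyl in place of hydroxymethyl

The compounds below may be only part of what the source reports. "The series", "measured", "known", "first", "only" and "open" are said of these compounds alone.

Measured so far in a functional assay on MDA-MB-231 cells (Homo sapiens) for antiproliferative activity, read by MTT assay, with a stated time of 72 h; a higher number here means a weaker inhibitor, a lower number a stronger inhibitor:
compound 1 `CC1=CCC2C(CC[C@@]2(C)O)C(C)(C)C1CC[C@@H]1[C@@]2(C)CC[C@@H](O)C(C)(C)O[C@@H]2CC[C@]1(C)O` sits at the limit > 50000 nM
compound 2 `CC1=C(CC[C@H]2[C@]3(C)CC[C@H](O)C(C)(C)O[C@H]3CC[C@@]2(C)O)[C@](C)(C/C=C/C(C)(C)OO)[C@H](O)CC1` sits at the limit > 50000 nM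
compound 3 `CC1(C)O[C@H]2CC[C@@](C)(O)[C@@H](CC[C@@H]3C(CO)=CC[C@H]4[C@H](CC[C@]4(C)O)C3(C)C)[C@]2(C)CC[C@@H]1O` sits at the limit > 50000 nM

Every value shown is a limit and not a number. Compound 3 stands where compound 1 and compound 2 also stand, at the limit (the limit of > 50000 nM in this assay, at which 3 of the 3 values shown sit); no order among the three can be read from this. Compound 4 `CC1(C)O[C@H]2CC[C@@](C)(O)[C@@H](CC[C@@H]3C(C=O)=CC[C@H]4[C@H](CC[C@]4(C)O)C3(C)C)[C@]2(C)CC[C@@H]1O` differs from compound 3 by formyl in place of hydroxymethyl on a double-bonded ring carbon. Going by the values given here, no measured step between any two compounds exists, so the size of this change has no precedent. The expected step from compound 3 to compound 4 is a step that the limit leaves unreadable from compound 3 to compound 4, that is, none beyond the usual scatter. Compound 4 is therefore expected at 60000 nM, within 15000 nM to 250000 nM.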

Compound 4, half-maximal inhibitory concentration: > 50000 nM
Compound 4 gave a limit, no number (the forecaster's own chance of this, stated with the estimate: 75%); the middle value is on the limit's open side.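

In this assay no step can be read between compound 3 and compound 4, as both values are limits: the limit of > 50000 nM in this assay, at which 4 of the 4 values shown sit.

The compounds shown leave open whether formyl in place of hydroxymethyl changes activity at all, and whether any change to the shared core gives a readable value.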